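Bromo in place of ethyl: one number to go on

A few compounds are considered here, and "the series" means these few. Any claim that something is new, unique, unknown or untested is made for them only; others in the source may bear on it.

Among the measured compounds shown here, in a functional assay on aorta (Rattus norvegicus) for inhibition (a higher number here means a weaker inhibitor, a lower number a stronger inhibitor), compound 1 `O=C(Nc1cc2cc[nH]c(=O)c2cc1Cl)C1CNCC1c1ccccn1` gives 210 nM as its half-maximal inhibitory concentration, the only number so far. Compound 2 `CCc1cccc(C2CNCC2C(=O)Nc2cc3cc[nH]c(=O)c3cc2Cl)c1` carries a 3-ethylphenyl group. In this assay compound 2 stands at "not determined" (no result reported) and no result, so it has no place on the scale and cannot be ranked against compound 1. Compound 3 `O=C(Nc1cc2cc[nH]c(=O)c2cc1Cl)C1CNCC1c1cccc(Br)c1` awaits measurement. The structural change bromo in place of ethyl on an aromatic carbon puts bromo in place of ethyl on an aromatic carbon, which reads as 3-ethylphenyl to 3-bromophenyl when cut one bond further out. For the measured compounds named here, no step between measured compounds is available, so the data give no direct size for this change in this assay and no direction for it. No step beyond the scatter is expected from this change alone. The estimate therefore rests on compound 1 at 210 nM as its sole anchor, and the range is kept wide. For compound 3 the expected value is 200 nM with an estimated range from 50 nM to 800 nM in this assay.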

Compound 3, half-maximal inhibitory concentration: 63 nM
Compound 3: middle estimate off by 3.2-fold (0.50 log units), on the high side; the measured number falls inside the stated range.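

In this assay, among the compounds shown here, 3-bromophenyl in place of pyridin-2-yl on a saturated ring carbon gives a 3.3-fold lower number from compound 1 to compound 3 (0.52 log units; beyond the scatter), the first step that can be read, and it lies beyond the scatter; this carbon therefore responds to the group it carries, and a phenyl ring with a bromo substituent is accepted there with a lower number than the pyridin-2-yl group. On these data alone, the change of ethyl to bromo itself cannot be read, since compound 2 has no number, so the size and direction of that exchange stay unknown and the result says nothing about bromo compared with ethyl. No measurement on hand bears on why the number falls from one aryl group to the other.

For the compounds shown here, the single readable step changes the ring and adds the bromo at once, so the share of each cannot be separated without a plain unsubstituted phenyl group at this carbon. Also open, as far as these compounds go, is how the number responds when the bromo gives way to a different kind of group on the same ring, such as an amine or a carboxylic acid.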